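This account rests on a few compounds, and the source may have more. Where it says the series, first, only, none or still open, it means among the compounds named here.

Measured compounds, a functional assay on HL-60 cells (Homo sapiens) for inhibition, read by MTT assay, with a stated time of 72 h; on this read-out higher numbers stand for weaker inhibition and lower numbers for stronger inhibition:
compound 1 `COc1ccc(-c2nc(C)oc2C(=O)N2CCN(c3cccc(Cl)c3)CC2)cc1O`: "not active" (no number reported)
compound 2 `Cc1nc(-c2ccccc2)c(C(=O)N2CCN(c3cccc(C#N)c3)CC2)o1`: 39.6 nM
compound 3 `Cc1nc(-c2ccccc2Cl)c(C(=O)N2CCN(c3cccc(Cl)c3)CC2)o1`: 132 nM

Compound 2 holds the lower of the two reported numbers; compound 3 sits above it by a margin beyond the usual scatter, and compound 1 returned no number at all. Going by the values given here, no pair of measured compounds differs in a single place, so no step is available to lean on. Compound 4 `Cc1cc(C)cc(N2CCN(C(=O)c3oc(C)nc3-c3ccccc3)CC2)c1` differs from compound 2 by 3,5-dimethylphenyl in place of 3-cyanophenyl on an amine nitrogen in a ring. Among the compounds with values here, the only other measured compound without the 3-cyanophenyl that carries a number, compound 3, differs from compound 2 in a second place as well, so its value cannot be read as the effect of this change alone. A modest step toward weaker inhibition in this assay is expected, not clearly beyond the scatter. Compound 4 is estimated at 80 nM (range 25 nM to 300 nM). The expected step is then a 2.0-fold higher number from compound 2 to compound 4 (0.31 log units; beyond the scatter).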

Compound 4, half-maximal inhibitory concentration: 34.5 nM
Compound 4: middle estimate off by 2.3-fold (0.37 log units), on the high side, within the range that was stated.
By their numbers in this assay, from the lowest: compounds 4 and 2 (each within the scatter of the next); then compound 3.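

At this position, on the amine nitrogen in the ring, 3,5-dimethylphenyl in place of 3-cyanophenyl gives a 1.1-fold lower number from compound 2 to compound 4 (0.06 log units; within the scatter) in this assay. The nitrile is therefore not needed for a number of this size on the shared core, and a carbon-only group serves equally well. Going by these compounds alone, this is the first single-place step, and it concerns this change alone.

Still open, from the compounds shown here alone, is how an unsubstituted phenyl, a methoxy group or an amine on this ring would compare. No measurement shown accounts for the match between these two groups.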